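This account rests on a few compounds, and the source may have more. Where it says the series, first, only, none or still open, it means among the compounds named here.

In a functional assay on A-431 cells (Homo sapiens) for cytotoxicity, read by MTT assay, with a stated time of 72 h, tested at 30 uM (a higher number here means more inhibition of growth at the concentration tested, a lower number less inhibition of growth), three compounds of this series have been measured so far. Compound 1 `Cc1ccnc(/C(N)=N/NC(=S)N2CCCC2)c1` gives 84.2%, compound 2 `Cc1ccnc(/C(N)=N/NC(=S)N2CCCCCC2)c1` gives 63.4%, and compound 3 `N/C(=N\NC(=S)N1CCOCC1)c1ccccn1` gives 78.8%. Compound 2 therefore stands lowest of the three: compound 3 is nearest, its number higher by more than the scatter, and compound 1 is furthest, also higher by more than the scatter. Compound 4 `N/C(=N\NC(=S)N1CCCCCC1)c1ccccn1` has not yet been measured in this assay. It differs from compound 2 in one place: hydrogen in place of methyl on an aromatic carbon. For the measured compounds named here, no measured pair shows this change alone, so nothing measured tells its size. The change is expected to shift the number only a little, a number 1.6 percentage points higher from compound 2 to compound 4 (within the scatter), in no definite direction and possibly not beyond the scatter. Compound 4 is accordingly estimated to give 65%, between 45% and 85%.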

Compound 4, percent growth inhibition at one concentration: 72.3%
Compound 4: the middle estimate sits 7.3 percentage points below what was measured; low and high end bracket the measured number.
By their numbers in this assay, from the lowest: compounds 2, 4, 3 and 1 (each within the scatter of the next, the first and the last beyond it).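

For the compounds shown here, with this pair, the replacement of methyl by hydrogen on an aromatic carbon, opposite the ring nitrogen, can be read alone for the first time: in this assay it gives a number 8.9 percentage points higher from compound 2 to compound 4 (within the scatter). On this one pair, the methyl at this position is not shown to matter for the read-out. Nothing measured here bears on why the step has this size. On these data alone, the step rests on a single pair, so whether it holds elsewhere stays open. Also open, as far as these compounds go, is what another group at this place, such as an ethyl chain, a methoxy group or an amine, would give.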